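Methylcarbamoyl to ethylcarbamoyl on the shared core

A few compounds are considered here, and "the series" means these few. Any claim that something is new, unique, unknown or untested is made for them only; others in the source may bear on it.

Measured in a functional assay on HCT-116 cells (Homo sapiens) for inhibition; on this read-out lower numbers stand for stronger inhibition and higher numbers for weaker inhibition
- compound 1 `CCNC(=O)c1noc(-c2cc(C(C)C)c(O)cc2O)c1-c1cc(COCC(=O)OC)no1` gives 262 nM
- compound 2 `CCNC(=O)c1noc(-c2cc(C(C)C)c(O)cc2O)c1-c1cc(C(=O)NC)no1` gives 124 nM

Of the two numbers in this assay, the lower belongs to compound 2 at 124 nM and sets the reference here. Compound 3 `CCNC(=O)c1cc(-c2c(C(=O)NCC)noc2-c2cc(C(C)C)c(O)cc2O)on1` differs from it by methyl in place of hydrogen on a saturated chain carbon bound to an amide-type nitrogen, so methylcarbamoyl becomes ethylcarbamoyl. Within the data shown here, the sole measured step, a 2.1-fold lower number from compound 1 to compound 2 (0.32 log units; beyond the scatter), exchanged a different group on an aromatic carbon and only loosely bears on this change. No step beyond the scatter is therefore expected, and no direction can be favoured. The estimate amounts to a 1.0-fold higher number from compound 2 to compound 3 (0.02 log units; within the scatter) as the expected step. Compound 3 is expected at 130 nM, within an estimated range of 60 nM to 280 nM in this assay.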

Compound 3, half-maximal inhibitory concentration: 14 nM
Beside the measured number, compound 3's estimate is 9.3-fold (0.97 log units) above it; measured number outside the range, below it.
By their numbers in this assay, from the lowest: compound 3; then compound 2; then compound 1.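

In this assay this position responds strongly to a very small change: methyl in place of hydrogen on a saturated chain carbon bound to an amide-type nitrogen, a single added carbon, gives an 8.9-fold lower number from compound 2 to compound 3 (0.95 log units; beyond the scatter). The earlier compounds shown here did not show that methylcarbamoyl to ethylcarbamoyl could matter this much, and ethylcarbamoyl in place of ((methoxycarbonyl)methoxy)methyl gives a 19-fold lower number from compound 1 to compound 3 (1.27 log units; beyond the scatter). No supporting data explain this gain. Still open, as far as these compounds go, is whether a longer chain, such as propylcarbamoyl or butylcarbamoyl, extends the trend or reverses it.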